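This account rests on a few compounds, and the source may have more. Where it says the series, first, only, none or still open, it means among the compounds named here.

Working notes on the series.

Compound 1 is `O=C(Nc1nc2ccccc2s1)c1cn(-c2ccccc2)nc1-c1ccc(Cl)cc1`. In a functional assay on U-87MG ATCC cells for cytotoxicity against U-87 MG (Homo sapiens), read by MTT assay, with a stated time of 72 h (a higher number here means a weaker inhibitor, a lower number a stronger inhibitor), compound 1 gives 11500 nM. Compound 2 is `O=C(Nc1nc2ccc(Cl)cc2s1)c1cn(-c2ccccc2)nc1-c1ccc(Cl)cc1`, and in this assay compound 2 gives 5870 nM; the two cores differ by hydrogen in place of chloro on an aromatic carbon. Compound 3 is `COc1ccc2nc(NC(=O)c3cn(-c4ccccc4)nc3-c3ccc(Cl)cc3)sc2c1`, and in this assay compound 3 gives 21200 nM. The step of a 3.6-fold higher number from compound 2 to compound 3 (0.56 log units; beyond the scatter) belongs to the change (methoxy in place of chloro on an aromatic carbon).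

Compound 4, not yet measured, is `COc1ccc(-c2nn(-c3ccccc3)cc2C(=O)Nc2nc3ccccc3s2)cc1`. It differs from compound 1 by methoxy in place of chloro on an aromatic carbon. This is the same kind of change as that from compound 2 to compound 3, but not the same: in compound 3 the place is part of a fused or bridged system of two rings, meta to a fused ring and para to a fused ring, whereas in compound 4 the place is a six-membered aromatic ring of carbon only, para to a large group. The measured occurrence of the change lies beyond the scatter and gives a higher number. How far that carries to another ring is not known from these compounds, so a smaller step is expected. The step expected in this assay is a 1.6-fold higher number from compound 1 to compound 4 (0.19 log units; within the scatter), which rests on the measured step of a 3.6-fold higher number from compound 2 to compound 3 (0.56 log units; beyond the scatter) and on compound 1 at 11500 nM. Compound 4 is therefore estimated at 18000 nM in this assay. For compound 4 the expected range runs from 7000 nM to 45000 nM.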

Compound 4, half-maximal inhibitory concentration: 11500 nM
Compound 4: middle estimate off by 1.6-fold (0.19 log units), on the high side, within the range that was stated.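

In this assay, going from 4-chlorophenyl to 4-methoxyphenyl gives no change at the digits printed from compound 1 to compound 4 (within the scatter), so methoxy in place of chloro on the six-membered aromatic ring of carbon only leaves no readable difference between these two compounds. The same kind of change on the fused system of two rings, in compound 2 and compound 3, did not predict this result, and the two occurrences differ: the same change on two cores in this assay, a 3.6-fold higher number (0.56 log units; beyond the scatter) from compound 2 to compound 3 and no change at the digits printed (within the scatter) from compound 1 to compound 4, 3.6-fold (0.56 log units) apart, beyond the scatter of two such steps. Among these compounds, this shows that the size of the step cannot be carried unchanged from one part of the series to another, but with only one measured pair for each place, it does not show why the steps differ or establish a general rule for either place.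

The compounds shown leave open how other groups, such as an amine, a carboxylic acid or a longer chain, would read at the place para to a large group in this assay. They also leave open whether a change at that place and a change on the fused system would act independently when made together, since each compound shown has only one of the two places varied from compound 1.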